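Fused bicyclic amine in place of the pyrrolidine side chain

The source may report more compounds than this note shows. Statements on the series, on what has been measured and on what is new or still open speak of the compounds shown alone.

Measured so far:
compound 1 `O=C(O)c1cn(Cc2ccc(-n3cccn3)cc2)c2cc(N3C[C@H]4CCNC[C@H]4C3)c(F)cc2c1=O`: 31300 nM
compound 2 `CNC[C@@H]1CCN(c2cc3c(cc2F)c(=O)c(C(=O)O)cn3Cc2ccc(-n3cccn3)cc2)C1`: > 200000 nM
compound 3 `CNC(=O)c1cn(Cc2ccc(-c3ccccc3)cc2)c2c(OC)c(N3CC[C@@H](CN)C3)c(F)cc2c1=O`: 82100 nM

In an assay on isolated protein for inhibition of DNA topoisomerase 1 (Homo sapiens), with a stated time of 15 min (on this read-out lower numbers stand for stronger inhibition and higher numbers for weaker inhibition), compound 1 gives 31300 nM and compound 3 gives 82100 nM. For compound 2 only a limit is known, (the limit of > 200000 nM in this assay, at which 1 of the 3 values shown sits), so its true value is not pinned down. Among the measured compounds shown here, the one step that bears on the present change is an at least 6.3-fold higher number from compound 1 to compound 2 (0.80 log units; beyond the scatter), in which a fused two-ring amine gave way to the 3-((methylamino)methyl)pyrrolidin-1-yl group. Compound 4 `O=C(O)c1cn(Cc2ccc(-n3cccn3)cc2)c2cc(N3CC4CNCC4C3)c(F)cc2c1=O` now carries a group of 8 heavy atoms (6 carbon, 2 nitrogen; 2 five-membered non-aromatic rings with 1 hetero atom each) in place of a group of 8 heavy atoms (6 carbon, 2 nitrogen; one five-membered non-aromatic ring with 1 hetero atom), on an aromatic carbon, so a fused two-ring amine returns. Given an at least 6.3-fold higher number from compound 1 to compound 2 (0.80 log units; beyond the scatter), the number for compound 4 is expected to move back into the measurable range. Compound 4 is estimated at 60000 nM, with a range of 15000 nM to 200000 nM, the expected step being an at least 3.3-fold lower number from compound 2 to compound 4 (0.52 log units; beyond the scatter).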

Compound 4, half-maximal inhibitory concentration: 173000 nM
The estimate for compound 4 lay 2.9-fold (0.46 log units) below the measured number; measured number inside the range.
By their numbers in this assay, from the lowest: compound 1; then compound 3; then compound 4. At a limit, above all of these: compound 2.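

The fused amine with two five-membered rings does not match the one with a five- and a six-membered ring, the change giving a 5.5-fold higher number from compound 1 to compound 4 (0.74 log units; beyond the scatter). A fused two-ring amine alone therefore does not bring back the number of compound 1, and the comparison with the 3-((methylamino)methyl)pyrrolidin-1-yl group gives only an at least 1.1-fold lower number from compound 2 to compound 4 (0.06 log units; that floor lies within the scatter). Compound 2 stands at a limit, not a number: the limit of > 200000 nM in this assay, at which 1 of the 4 values shown sits.

On these data alone, whether compound 4 truly differs from compound 2 stays open. So does what a fused amine of two six-membered rings would give on the shared core.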